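The source may hold more compounds than are shown below. What is called first, only, known or untested is meant among the compounds shown, and "the series" means these compounds.

Measured in a functional assay on the whole organism with Rattus norvegicus as the target; on this read-out lower numbers stand for an effect already at smaller amounts and higher numbers for an effect only at larger amounts of compound:
- Compound 1 `CS(=O)(=O)c1ccc(-c2[nH]ccc2-c2ccc(F)cc2)cc1`: > 317 uM (a limit, not a number)
- Compound 2 `CS(=O)(=O)c1ccc(-c2[nH]c(Br)c(Cl)c2-c2ccc(F)cc2)cc1`: 9.98 uM

Within the data shown here, compound 2 gives 9.98 uM, the only actual number so far. The other reading is the limit of > 317 uM in this assay, at which 1 of the 2 values shown sits.

Compound 3 `CS(=O)(=O)c1ccc(-c2[nH]c(Br)cc2-c2ccc(F)cc2)cc1` has hydrogen in place of chloro on an aromatic carbon, next to the ring atom that bears a bromo group. Among the measured compounds shown here, no measured step isolates this change, so the expectation is loose.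

Compound 1 reads > 317 uM, and this limit is the only sign of how far the series can fall. Compound 3 keeps the bromo group, so a moderate move toward a higher number is expected in this assay, estimated as a 3.0-fold higher number from compound 2 to compound 3 (0.48 log units; beyond the scatter). A reading at the limit cannot be ruled out.

For compound 3 the expected value is 30 uM, with an estimated range of 8 uM to 150 uM.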

Compound 3, concentration for half-maximal effect: 2.66 uM
For compound 3 the middle estimate is 11-fold (1.05 log units) above the measured one; the measured number lies below the stated range.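

In this assay, the chloro group on this aromatic carbon is not needed for the effect: with the bromo group kept, hydrogen in its place gives a 3.8-fold lower number from compound 2 to compound 3 (0.57 log units; beyond the scatter). The bromo group is the change that matters most among the compounds shown, with an at least 110-fold lower number from compound 1 to compound 3 (2.07 log units; beyond the scatter). From the compounds shown here alone, compound 1 is a limit, not a number, so the size of that step stays open on one side: the limit of > 317 uM in this assay, at which 1 of the 3 values shown sits.

Open, going by these compounds, is whether the gain depends on bromo itself or whether another group on the same carbon, such as methyl or nitrile, would give a similar reading. Also open, on these data alone, is what chloro does without bromo on the ring, and whether a methoxy group or an amine on the carbon now bearing hydrogen would shift the reading further.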